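Imidazolyl compound 3: 2-chlorophenyl for 4-nitrophenyl

The compounds below may be only part of what the source reports. "The series", "measured", "known", "first", "only" and "open" are said of these compounds alone.

Values in a functional assay on HepG2 cells (Homo sapiens) for cytotoxicity, read by MTT assay, with a stated time of 48 h; on this read-out lower numbers stand for stronger inhibition and higher numbers for weaker inhibition:
- compound 1 `O=c1cc(-c2ccc([N+](=O)[O-])cc2)oc2c(CN3CCCCC3)cc(Cl)cc12` gives 8910 nM
- compound 2 `CN(C)Cc1cc(Cl)cc2c(=O)cc(-c3ccc([N+](=O)[O-])cc3)oc12` gives 6190 nM
- compound 3 `O=c1cc(-c2ccc([N+](=O)[O-])cc2)oc2c(Cn3ccnc3)cc(Cl)cc12` gives 2940 nM

Compound 3 has the lowest number of the three, with a 2.1-fold lower number from compound 2 to compound 3 (0.32 log units; beyond the scatter) and a 3.0-fold lower number from compound 1 to compound 3 (0.48 log units; beyond the scatter). The remaining comparison is a 1.4-fold lower number from compound 1 to compound 2 (0.16 log units; within the scatter).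

Compound 4 `O=c1cc(-c2ccccc2Cl)oc2c(Cn3ccnc3)cc(Cl)cc12` keeps the 1H-imidazol-1-yl group of compound 3 but has 2-chlorophenyl in place of 4-nitrophenyl on an aromatic carbon, next to the ring oxygen: 2-chlorophenyl in place of 4-nitrophenyl on an aromatic carbon.

Going by the values given here, no measured step changes this aryl group. All three change the group on the saturated chain carbon, so they bear on the new step only as a guide to size, the largest being a 3.0-fold lower number from compound 1 to compound 3 (0.48 log units; beyond the scatter). They give no direction. A step of similar size or smaller is therefore expected in this assay, with a slight lean towards a higher number and a wide margin either way. The expected change is a 1.4-fold higher number from compound 3 to compound 4 (0.13 log units; within the scatter). Compound 4 is estimated at 4000 nM, with an expected range of 1300 nM to 12000 nM.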

Compound 4, half-maximal inhibitory concentration: 3270 nM
Compound 4: middle estimate off by 1.2-fold (0.09 log units), on the high side; the range from low to high includes it.
By their numbers in this assay, from the lowest: compounds 3, 4, 2 and 1 (each within the scatter of the next, the first and the last beyond it).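

In this assay, 2-chlorophenyl in place of 4-nitrophenyl on this aromatic carbon, next to the ring oxygen, gives a 1.1-fold higher number from compound 3 to compound 4 (0.05 log units; within the scatter), so this pair does not separate the two aryl groups. The earlier steps shown here changed only the group on the saturated chain carbon; this one shows that, with 1H-imidazol-1-yl held fixed, going from 9 to 7 heavy atoms and from 2 hydrogen-bond acceptors to 0 in the aryl group leaves the change within the scatter. No evidence at hand bears on why the value holds.

On these data alone, whether 2-chlorophenyl gives the same result with dimethylamino or piperidin-1-yl on the chain carbon stays open. So does the outcome at this position with a different aryl group, such as 4-aminophenyl or 4-carboxyphenyl.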